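Side-chain replacement on the shared core: ester to carbamoyl

A few compounds are considered here, and "the series" means these few. Any claim that something is new, unique, unknown or untested is made for them only; others in the source may bear on it.

Compound 2 `O=C(CN(c1nc(Cl)nc2[nH]cnc12)C1CC1)N[C@@H](CCC(=O)OCc1ccccc1)C(=O)OCc1ccccc1` is the stronger of the two compounds measured; in a functional assay on the whole organism (Tail, strain ICR) with Mus musculus as the target, in the tail flick test, with a stated time of 150 min, at a dose of 25 umol/kg by the oral route (on this read-out higher numbers stand for a stronger effect at the one dose given and lower numbers for a weaker effect), compound 2 gives 44.5%, the highest of the two numbers. Among the measured compounds shown here, compound 1 `N=C(N)NCCC[C@H](NC(=O)CN(c1nc(Cl)nc2[nH]cnc12)C1CC1)C(=O)OCc1ccccc1` gives 6.12% in this assay, and the one measured step, a number 38.4 percentage points higher from compound 1 to compound 2 (beyond the scatter), is large and beyond the scatter. Compound 3 `NC(=O)C[C@H](NC(=O)CN(c1nc(Cl)nc2[nH]cnc12)C1CC1)C(=O)OCc1ccccc1` is not yet measured. It differs from compound 2 by carbamoyl in place of (benzyloxycarbonyl)methyl on a saturated chain carbon, two bonds along the chain from an amide-type nitrogen and a carbonyl carbon. For the measured compounds named here, the only step that bears on this change is the one from compound 1 to compound 2, where a group without a ring was exchanged for one carrying a six-membered aromatic ring and the number rose sharply; the present change runs the other way, a group with a six-membered aromatic ring and two hydrogen-bond acceptors giving way to carbamoyl with one hydrogen-bond donor. A drop beyond the scatter is therefore expected, roughly a number 29.5 percentage points lower from compound 2 to compound 3 (beyond the scatter). For compound 3 the expected value in this assay is 15%, within 0% to 35%.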

Compound 3, a percentage reported as activity, at one dose (the size of the read-out at that dose, not a potency): 13.5%
Compound 3: the middle estimate sits 1.5 percentage points above what was measured; the measured number falls inside the stated range.
By their numbers in this assay, from the lowest: compounds 1 and 3 (each within the scatter of the next); then compound 2.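

In this assay the change to carbamoyl gives a number 31 percentage points lower from compound 2 to compound 3 (beyond the scatter) and shows that the high number of compound 2 does not survive the loss of (benzyloxycarbonyl)methyl at this position. Among the compounds shown here, the other ringless side chain gives no separation, with a number 7.4 percentage points higher from compound 1 to compound 3 (within the scatter) and so no order between these two compounds, which means that among the three compounds only the one carrying the six-membered aromatic ring stands apart. No measurement at hand accounts for these steps.

This change removes the ester and the aromatic ring and shortens the chain all at once, so the compounds shown do not say which of these matters. A carboxylic acid, a methyl ester or a phenyl group on a chain of the same length as in compound 2 would separate these parts.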